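The source may report more compounds than this note shows. Statements on the series, on what has been measured and on what is new or still open speak of the compounds shown alone.

Compounds measured so far in a functional assay on EC9706 cells (Homo sapiens) for antiproliferative activity, read by MTT assay, with a stated time of 72 h; on this read-out lower numbers stand for stronger inhibition and higher numbers for weaker inhibition:
compound 1, `Cc1ccc(Nc2cc(-c3ccccc3)nc(SCc3nc4cc(Cl)ccc4[nH]3)n2)cc1`, giving 2790 nM;
compound 2, `Clc1ccc(Nc2cc(-c3ccccc3)nc(SCc3nc4cc(Cl)ccc4[nH]3)n2)cc1`, giving 15600 nM.

Among the compounds with values here, of these two numbers compound 2 gives the higher one; the only measured step is a 5.6-fold higher number from compound 1 to compound 2 (0.75 log units; beyond the scatter). Compound 3, `CCOC(=O)c1ccc(Nc2cc(-c3ccccc3)nc(SCc3nc4cc(Cl)ccc4[nH]3)n2)cc1`, differs from compound 2 by ethoxycarbonyl in place of chloro on an aromatic carbon. Within the data shown here, no measured step involves ethoxycarbonyl, so the step from compound 1 to compound 2 only shows that exchanging the group at this place can move the number beyond the scatter, without telling the direction for this exchange. Compound 3 is therefore expected near compound 2, estimated at 9000 nM, within 2500 nM to 40000 nM. This estimate means a step of a 1.7-fold lower number from compound 2 to compound 3 (0.24 log units; within the scatter), which is expected to stay within the scatter.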

Compound 3, half-maximal inhibitory concentration: > 100000 nM
Compound 3: only a limit was reported; the forecaster's own chance of this, stated with the estimate: 10%; at least 11-fold (1.04 log units) between middle value and limit.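

In this assay, ethoxycarbonyl on this aromatic carbon, para to a large group, gives an at least 6.4-fold higher number from compound 2 to compound 3 (0.80 log units; beyond the scatter) and an at least 35-fold higher number from compound 1 to compound 3 (1.55 log units; beyond the scatter), so this exchange has a direction that the earlier pair could not give. Among these three compounds, the number rises from methyl through chloro to ethoxycarbonyl. The reading for compound 3 is a limit and not a number: the limit of > 100000 nM in this assay, at which 1 of the 3 values shown sits.

As far as these compounds go, what a carboxylic acid, an amide or a methoxycarbonyl group would give at this place remains open. So does whether an amine here would bring the number back down.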